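Extending the Ether Chain of Compound 2 with a Ketone

This account rests on a few compounds, and the source may have more. Where it says the series, first, only, none or still open, it means among the compounds named here.

Three compounds share a core in which an acetyl group and a hydroxyl sit on an aromatic ring carrying an ether chain. For the measured compounds named here, in an assay on isolated protein for inhibition of leukotriene B4 receptor 1 (Homo sapiens), tested at 10 uM (on this read-out higher numbers stand for more inhibition at the one concentration tested (going by the name of the read-out) and lower numbers for less inhibition), compound 1 `CCc1cc(C(C)=O)c(O)cc1OCCCC(C)(C)C(N)=O` gives 92% and compound 3 `CCc1cc(C(C)=O)c(O)cc1OCCCCCCSC` gives 71%; the only measured step, a number 21 percentage points lower from compound 1 to compound 3 (beyond the scatter), swaps one chain end for another on the same long chain. Compound 2 `C=CCc1cc(C(C)=O)c(O)cc1OCCCC` carries a plain butyl chain and gives 32%, the lowest of the three, beyond the scatter below both compound 3 and compound 1. Compound 2 also differs from those two in the small group on the ring, so no single step explains its lower number.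

Compound 4 `C=CCc1cc(C(C)=O)c(O)cc1OCCCCCC(C)=O` keeps the core of compound 2 and lengthens its chain: 2-oxopropyl in place of hydrogen on a saturated chain carbon, four bonds along the chain from an oxygen on an aromatic ring. The two longer chains of compound 1 and compound 3 both came with higher numbers than the short chain of compound 2, so a rise is expected in this assay. The estimated step is a number 30 percentage points higher from compound 2 to compound 4 (beyond the scatter), and compound 4 is expected to give 62%, within 38% to 85%.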

Compound 4, a percentage reported as inhibition, at one concentration (the size of the read-out at that concentration, not a potency): 98%
Compound 4: the middle estimate sits 36 percentage points below what was measured; the measured number lies above the stated range.
By their numbers in this assay, from the lowest: compound 2; then compound 3; then compounds 1 and 4 (each within the scatter of the next).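

At this position, four bonds along the chain from an oxygen on an aromatic ring, putting 2-oxopropyl in place of hydrogen gives, in this assay, a number 66 percentage points higher from compound 2 to compound 4 (beyond the scatter) with the core of compound 2 unchanged. The earlier compounds shown here could not show this: compound 2 differed from compound 1 and compound 3 in the small group on the ring as well as in the chain, whereas here only the chain differs. Nothing measured here explains why this change raises the number.

As far as these compounds go, it remains open whether the carbonyl or the added chain length carries the step, a question that a plain alkyl chain of the same length on this core would address. Also open, from the compounds shown here alone, is how a carboxylic acid or an amine at the chain end would read out.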